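Replacing an aromatic ring with cyclohexyl in compound 3

The source may hold more compounds than are shown below. What is called first, only, known or untested is meant among the compounds shown, and "the series" means these compounds.

Compound 1 `CC(=O)N1CC[C@@H](C(=O)N2CC[C@](c3ccc(C(OCc4c(F)cccc4F)(C(F)(F)F)C(F)(F)F)cc3)(S(=O)(=O)c3ccc(F)cc3)C2)C1` gives 9%
Compound 2 `CC(=O)N1CCN(C(=O)N2CC[C@](c3ccc(C(OCc4c(F)cccc4F)(C(F)(F)F)C(F)(F)F)cc3)(S(=O)(=O)c3ccc(F)cc3)C2)CC1` gives 5%
Compound 3 `Cc1cccc(F)c1COC(c1ccc([C@]2(S(=O)(=O)c3ccc(F)cc3)CCN(C(=O)[C@H]3CC[C@H](C(=O)O)CC3)C2)cc1)(C(F)(F)F)C(F)(F)F` gives 79%

In an ADME assay on microsomes from liver (Homo sapiens) for metabolic stability, with a stated time of 10 min (a lower number here means that less of the compound is left, a higher number that more of the compound is left), compound 3 stands highest of the three, and its gaps to compound 1 and compound 2 both lie beyond the scatter. The change from compound 3 to compound 4 `O=C(O)[C@H]1CC[C@H](C(=O)N2CC[C@](c3ccc(C(OCC4CCCCC4)(C(F)(F)F)C(F)(F)F)cc3)(S(=O)(=O)c3ccc(F)cc3)C2)CC1` is cyclohexyl in place of 2-fluoro-6-methylphenyl on a saturated chain carbon bound to an oxygen on a saturated carbon and, in words, cyclohexyl in place of 2-fluoro-6-methylphenyl on a saturated chain carbon bound to an oxygen on a saturated carbon. Among the compounds with values here, the only measured step is a number 4 percentage points lower from compound 1 to compound 2 (within the scatter) and it sits on a carbonyl carbon, so it is a different change and offers little guidance here. Within the data shown here, no measured pair tests this swap directly. Compound 3 at 79% lies high on the scale, leaving more room to fall than to rise, so a moderate drop is expected, although no change beyond the scatter remains possible. The expected step is a number 19 percentage points lower from compound 3 to compound 4 (beyond the scatter) in this assay with wide uncertainty. For compound 4 the estimated value is 60% with an expected range from 30% to 85% on this limited evidence.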

Compound 4, percent of the compound remaining: 92%
Beside the measured number, compound 4's estimate is 32 percentage points below it; measured number above the stated range.
By their numbers in this assay, from the lowest: compounds 2 and 1 (each within the scatter of the next); then compound 3; then compound 4.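

In this assay, putting cyclohexyl in place of 2-fluoro-6-methylphenyl gives a number 13 percentage points higher from compound 3 to compound 4 (beyond the scatter). Within the data shown here, this is the first measured change on a saturated chain carbon bound to an oxygen on a saturated carbon, and it shows that an aromatic ring bearing fluorine and methyl is not required there for a high number, as the non-aromatic ring of carbon only does better in this pair. The data shown offer no measured property that would explain this rise.

Going by these compounds, what remains open is whether the gain comes from losing the aromatic ring or from losing its fluorine and methyl, a question that a plain phenyl could help to separate. A cyclopentyl or a piperidine ring could show how much this group can vary while the number stays high.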